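The source may report more compounds than this note shows. Statements on the series, on what has been measured and on what is new or still open speak of the compounds shown alone.

Measured in a functional assay on Jurkat cells (Homo sapiens) for inhibition, read by CCK-8 assay, with a stated time of 48 h; on this read-out lower numbers stand for stronger inhibition of growth and higher numbers for weaker inhibition of growth:
- Compound 1 `Cc1ccc(Nc2ncc(Cl)c(Nc3ccccc3C)n2)cc1`: > 100000 nM, a limit
- Compound 2 `Cc1ccccc1Nc1nc(Nc2cc(Cl)ccn2)ncc1Cl`: 39600 nM

Among the measured compounds shown here, compound 2 holds the only actual number so far. Compound 3 `Cc1ccccc1Nc1nc(NCc2ccncc2)ncc1Cl` is still unmeasured and carries (pyridin-4-yl)methyl in place of 4-chloropyridin-2-yl on a nitrogen on an aromatic ring. For the measured compounds named here, one measured step bears on it: an at least 2.5-fold lower number from compound 1 to compound 2 (0.40 log units; beyond the scatter), at the same place, resting on a limit and involving a different incoming group. It shows that the place matters in this assay but gives no direction here. No change beyond the scatter is expected, with a slight lean towards weaker inhibition. The expected step is a 1.3-fold higher number from compound 2 to compound 3 (0.10 log units; within the scatter). The estimate for compound 3 is 50000 nM, with an expected range of 18000 nM to 100000 nM.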

Compound 3, concentration for 50% growth inhibition: > 100000 nM
Compound 3 gave a limit, no number (the forecaster's own chance of this, stated with the estimate: 30%); at least 2.0-fold (0.30 log units) between middle value and limit.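

In this assay, this nitrogen position now shows a direction for a second incoming group, and the result for compound 3 is a limit, not a number: an at least 2.5-fold higher number from compound 2 to compound 3 (0.40 log units; beyond the scatter). The lower number of compound 2 is therefore not kept when (pyridin-4-yl)methyl replaces 4-chloropyridin-2-yl. The step from compound 1 to compound 3 cannot be read, and the full size of the loss stays unknown: the limit of > 100000 nM in this assay, at which 2 of the 3 values shown sit.

Still open, on these data alone, is whether the chlorine or the methylene link matters more. A pyridine ring without chlorine, or a longer chain ending in pyridine, on this nitrogen would help separate the two.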